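Sulfonyl aryl exchange in the shared amide-sulfonamide series

The source may hold more compounds than are shown below. What is called first, only, known or untested is meant among the compounds shown, and "the series" means these compounds.

Measured so far:
compound 1: `O=C(NCc1ccc(CNS(=O)(=O)c2cccc(C(F)(F)F)c2)cc1)c1ccc(F)cc1`; in an assay on MDA-MB-231 cells for binding affinity to C-X-C chemokine receptor type 4 (Homo sapiens), read by fluorescence and microscopy, with stated times of 10 min and 30 min (on this read-out lower numbers stand for an effect already at smaller amounts and higher numbers for an effect only at larger amounts of compound), compound 1 gives 100 nM
compound 2: `O=C(NCc1ccc(CNS(=O)(=O)c2cccc(Cl)c2)cc1)c1ccc(F)cc1`; in this assay compound 2 gives 1 nM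

Compound 2 holds the lowest of the two numbers, and its nearest neighbour is compound 1: a 100-fold lower number from compound 1 to compound 2 (2.00 log units; beyond the scatter). That single step is also the only one that bears on the next move, since it too alters the aryl sitting on the sulfonyl sulfur, and it was large.

Compound 3 `Cc1ccccc1S(=O)(=O)NCc1ccc(CNC(=O)c2ccc(F)cc2)cc1` is not yet measured in this assay. It differs from compound 2 by 2-methylphenyl in place of 3-chlorophenyl on a sulfonyl sulfur.

Given that the one known exchange on this aryl moved the read-out far, and that compound 2 already stands at the lowest number, a step beyond the scatter toward a higher number is expected for compound 3, of about a 30-fold higher number from compound 2 to compound 3 (1.48 log units; beyond the scatter). The estimate for compound 3 is 30 nM, in the range 3 nM to 300 nM.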

Compound 3, effective concentration (reported as EC, without a stated level of effect): 100 nM
Compound 3: middle estimate off by 3.3-fold (0.52 log units), on the low side; measured number inside the range.
By their numbers in this assay, from the lowest: compound 2; then compounds 1 and 3 (each within the scatter of the next).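

In this assay, the low number of compound 2 does not carry over to a second aryl on the sulfonyl sulfur: 2-methylphenyl in place of 3-chlorophenyl gives a 100-fold higher number from compound 2 to compound 3 (2.00 log units; beyond the scatter), although both groups have the same printed counts of heavy atoms, hydrogen-bond donors and acceptors. With 2-methylphenyl in place of 3-(trifluoromethyl)phenyl there is no change at the digits printed from compound 1 to compound 3 (within the scatter), so among these three compounds only the 3-chlorophenyl of compound 2 stands apart, while two different aryls share one level. Nothing at hand explains this sensitivity to the aryl.

Compound 3 changes both the substituent and its place on the ring, so these two changes cannot be separated here. 3-Methylphenyl or 2-chlorophenyl on the sulfonyl sulfur would separate them, and 3-aminophenyl would test an amine there.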